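The source may hold more compounds than are shown below. What is called first, only, known or untested is meant among the compounds shown, and "the series" means these compounds.

Measured so far in a functional assay on CCRF-CEM cells (Homo sapiens) for antiproliferative activity, with a stated time of 72 h; on this read-out higher numbers stand for weaker inhibition and lower numbers for stronger inhibition:
- compound 1 `OC[C@H]1O[C@@H](n2cnc3c(NCc4cccc(F)c4)ncnc32)[C@H](O)[C@@H]1O`: 4000 nM
- compound 2 `OC[C@H]1O[C@@H](n2cnc3c(NCc4ccc(F)cc4)ncnc32)[C@H](O)[C@@H]1O`: 1250 nM
- compound 3 `Cc1cccc(CNc2ncnc3c2ncn3[C@@H]2O[C@H](CO)[C@@H](O)[C@H]2O)c1`: 19100 nM

Of these three, compound 3 carries the highest number, 19100 nM, which makes it the weakest inhibitor so far. The two steps that reach it are a 4.8-fold higher number from compound 1 to compound 3 (0.68 log units; beyond the scatter) and a 15-fold higher number from compound 2 to compound 3 (1.18 log units; beyond the scatter).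

The next compound, compound 4 `Cc1ccc(CNc2ncnc3c2ncn3[C@@H]2O[C@H](CO)[C@@H](O)[C@H]2O)cc1`, has not yet been measured. It has 4-methylphenyl in place of 3-methylphenyl on a saturated chain carbon bound to a nitrogen on an aromatic ring.

For the measured compounds named here, the closest precedent is the matching swap among the fluorinated compounds, which gave a 3.2-fold lower number from compound 1 to compound 2 (0.51 log units; beyond the scatter). That is a modest step toward stronger inhibition. Going by the values given here, it is also the only such pair, and it involves fluoro rather than methyl. Replacing fluoro with methyl is itself not neutral, as a 4.8-fold higher number from compound 1 to compound 3 (0.68 log units; beyond the scatter) shows, so the precedent may not carry over in full. A modest step in the same direction therefore seems the most reasonable expectation, though with wide uncertainty.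

The expected change is a 2.9-fold lower number from compound 3 to compound 4 (0.47 log units; beyond the scatter). For compound 4 the estimated value in this assay is 6500 nM, with an expected range from 2000 nM to 20000 nM.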

Compound 4, half-maximal inhibitory concentration: > 166000 nM
Compound 4: a limit, no number; the forecaster's own chance of this, stated with the estimate: 10%; at least 25-fold (1.40 log units) between middle value and limit.
By their numbers in this assay, from the lowest: compound 2; then compound 1; then compound 3. At a limit, above all of these: compound 4.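

In this assay compound 4 gives > 166000 nM, which is a limit of the assay and not a number. Moving the methyl, with 4-methylphenyl in place of 3-methylphenyl, gives an at least 8.6-fold higher number from compound 3 to compound 4 (0.93 log units; beyond the scatter), whereas the same move of fluoro gave a 3.2-fold lower number from compound 1 to compound 2 (0.51 log units; beyond the scatter), so on this saturated chain carbon the direction of the move depends on the group being moved. Methyl in place of fluoro is not a fixed change either, since 4-methylphenyl in place of 3-fluorophenyl gives an at least 41-fold higher number from compound 1 to compound 4 (1.61 log units; beyond the scatter), and the methyl-for-fluoro swap gives an at least 130-fold higher number from compound 2 to compound 4 (2.12 log units; beyond the scatter), a far larger step than the same swap on the other pair: the same change on two cores in this assay, a 4.8-fold higher number (0.68 log units; beyond the scatter) from compound 1 to compound 3 and an at least 130-fold higher number (2.12 log units; beyond the scatter) from compound 2 to compound 4, at least 27-fold (1.44 log units) apart, beyond the scatter of two such steps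

With only fluoro and methyl on this phenyl ring, the compounds shown leave open how other groups would behave there, such as a chlorine atom, a hydroxyl or an amine. From the compounds shown here alone, the true size of each step to compound 4 also stays open, as all three give only a lower bound.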